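Swapping chlorines for methyls on the aryl piperazine arm

This account rests on a few compounds, and the source may have more. Where it says the series, first, only, none or still open, it means among the compounds named here.

Of the compounds shown here, two have been measured in a functional assay on HCT-116 cells (Homo sapiens) for cytotoxicity, read by MTT assay, with a stated time of 2 days; a higher number here means a weaker inhibitor, a lower number a stronger inhibitor. Compound 2, `Clc1cccc(N2CCN(CCCCNc3nc(NCc4ccco4)c4ccccc4n3)CC2)c1Cl`, gives 3200 nM. Compound 1, `Cc1cccc(N2CCN(CCCCNc3nc(NCc4ccco4)c4cc(F)ccc4n3)CC2)c1C`, which carries a 2,3-dimethylphenyl group, gives 820 nM. Of the two numbers, compound 2 stands at the higher one, and the gap to compound 1 lies beyond the scatter of this assay.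

Compound 3, `Cc1cccc(N2CCN(CCCCNc3nc(NCc4ccco4)c4ccccc4n3)CC2)c1C`, has not yet been measured. It arises from compound 2 by a single change: 2,3-dimethylphenyl in place of 2,3-dichlorophenyl on an amine nitrogen in a ring. Among the measured compounds shown here, no measured pair isolates this exact change, so only an expectation can be given. Since compound 1, which shares the 2,3-dimethylphenyl group, gives 820 nM, compound 3 is expected to move in the same direction, toward a lower number. The step from compound 2 to compound 3 in this assay is estimated at a 2.5-fold lower number from compound 2 to compound 3 (0.39 log units; beyond the scatter). Compound 3 is therefore expected to give about 1300 nM, with a plausible range from 550 nM to 3200 nM.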

Compound 3, half-maximal inhibitory concentration: 840 nM
The estimate for compound 3 lay 1.5-fold (0.19 log units) above the measured number; the range from low to high includes it.
By their numbers in this assay, from the lowest: compounds 1 and 3 (each within the scatter of the next); then compound 2.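

The earlier compounds shown here offered no pair differing only in this place, but in this assay 2,3-dimethylphenyl in place of 2,3-dichlorophenyl on the amine nitrogen in the ring now gives a 3.8-fold lower number from compound 2 to compound 3 (0.58 log units; beyond the scatter) with everything else held fixed. Hydrogen in place of fluoro on an aromatic carbon gives a 1.0-fold higher number from compound 1 to compound 3 (0.01 log units; within the scatter), so with the 2,3-dimethylphenyl group present, this fluoro makes no difference that can be told from the scatter. Nothing at hand shows what lies behind either step.

On these data alone, it remains open whether an unsubstituted phenyl, a methoxyphenyl or a pyridine on that ring nitrogen would follow the same trend. As far as these compounds go, it is also open whether the fluoro would stay just as silent alongside the 2,3-dichlorophenyl group or with a longer chain.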